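Removing the Methoxy Group from a Bromo-Substituted Iminochromene Amide

The source may report more compounds than this note shows. Statements on the series, on what has been measured and on what is new or still open speak of the compounds shown alone.

Measured so far:
compound 1, `N=c1oc2ccc(Br)cc2cc1C(=O)NC1CCCCC1`: 5%
compound 2, `COc1cc(Br)cc2cc(C(=O)NCCCO)c(=N)oc12`: 31%

In an assay on CHO cells for displacement of a labelled ligand from adenosine receptor A1 (Homo sapiens), read by scintillation counting, with a stated time of 60 min, tested at 10 uM (a higher number here means more inhibition at the concentration tested (going by the name of the read-out), a lower number less inhibition), compound 2 gives 31%, the higher of the two measured values, while compound 1 gives 5%, a gap beyond the usual scatter. Within the data shown here, the two compounds differ in more than one place, so no single step is drawn between them. Compound 3, `N=c1oc2ccc(Br)cc2cc1C(=O)NCCCO`, differs from compound 2 in one place: hydrogen in place of methoxy on an aromatic carbon. Among the measured compounds shown here, with no directly comparable step in hand, a modest loss or no change beyond the scatter is expected, that is a number 11 percentage points lower from compound 2 to compound 3 (beyond the scatter). For compound 3 the expected value is 20%, with a range from 5% to 40%.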

Compound 3, a percentage reported as inhibition, at one concentration (the size of the read-out at that concentration, not a potency): 32%
Compound 3: the middle estimate sits 12 percentage points below what was measured; the range from low to high includes it.
By their numbers in this assay, from the lowest: compound 1; then compounds 2 and 3 (each within the scatter of the next).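

In this assay, hydrogen in place of methoxy on the aromatic carbon ortho to a fused ring gives a number 1 percentage points higher from compound 2 to compound 3 (within the scatter), so this change leaves the read-out level at this position. With the methoxy group out of the comparison, 3-hydroxypropyl in place of cyclohexyl on the amide-type nitrogen gives a number 27 percentage points higher from compound 1 to compound 3 (beyond the scatter), a single-place step that the first two compounds could not provide. No supporting data account for either result.

From the compounds shown here alone, whether an amine or a chloro group on that aromatic carbon would read the same remains open. So does whether a longer chain or a carboxylic acid on the amide-type nitrogen would keep this level.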